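A chloro on the benzyl ring of compound 3

The compounds below may be only part of what the source reports. "The series", "measured", "known", "first", "only" and "open" are said of these compounds alone.

Compound 3 `C=C(Br)C(=O)Nc1cccc(-c2cn3nc(Cc4ccccc4)sc3n2)c1` stands highest of the three numbers measured in a functional assay on HeLa cells (Homo sapiens) for inhibition, read by cell counting, with a stated time of 4 days (on this read-out lower numbers stand for stronger inhibition and higher numbers for weaker inhibition), where compound 3 gives 4500 nM. Its nearest neighbour is compound 1 `C=C(Br)C(=O)Nc1cccc(-c2cn3nc(-c4ccc(CC)cc4)sc3n2)c1`, and in this assay compound 1 gives 3200 nM; the step of a 1.4-fold higher number from compound 1 to compound 3 (0.15 log units; within the scatter) stays within the scatter. Compound 2 `C=C(Br)C(=O)Nc1cccc(-c2cn3nc(-c4ccc(F)cc4)sc3n2)c1` is furthest away, with compound 2 giving 870 nM in this assay, so that a 5.2-fold higher number from compound 2 to compound 3 (0.71 log units; beyond the scatter). Compound 4 `C=C(Br)C(=O)Nc1cccc(-c2cn3nc(Cc4ccc(Cl)cc4)sc3n2)c1` differs from compound 3 in one place: chloro in place of hydrogen on an aromatic carbon. Among the compounds with values here, no measured step puts chloro in place of hydrogen. Within the data shown here, the only step bearing on it is a 3.7-fold lower number from compound 1 to compound 2 (0.57 log units; beyond the scatter), a change of the group on an aromatic carbon of a six-membered aromatic ring of carbon only, in a compound carrying a 4-ethylphenyl rather than a benzyl; it shows that what sits there can move the number beyond the scatter. Compound 4 is therefore expected to show a modest step downward, a 1.8-fold lower number from compound 3 to compound 4 (0.26 log units; within the scatter), though this expectation rests on a single indirect comparison and a step within the scatter is also possible. The estimate for compound 4 is 2500 nM, with a range from 900 nM to 6500 nM.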

Compound 4, half-maximal inhibitory concentration: 2700 nM
Compound 4: the middle estimate sits 1.1-fold (0.03 log units) below what was measured; low and high end bracket the measured number.
By their numbers in this assay, from the lowest: compound 2; then compounds 4, 1 and 3 (each within the scatter of the next).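

In this assay, within the data shown here, chloro in place of hydrogen on the benzyl ring, para to a large group, gives the first direct reading of a change on this ring (a 1.7-fold lower number from compound 3 to compound 4 (0.22 log units; within the scatter)), so this addition does not separate compound 4 from compound 3. The 4-chlorobenzyl of compound 4 is likewise not separated from the 4-ethylphenyl of compound 1 (a 1.2-fold lower number from compound 1 to compound 4 (0.07 log units; within the scatter)), but a gap to the 4-fluorophenyl of compound 2 remains (a 3.1-fold higher number from compound 2 to compound 4 (0.49 log units; beyond the scatter)), leaving compound 2 the most potent of the four, with its steps to all three others beyond the scatter. That last step changes both the halogen and the benzyl or phenyl form of the group at once, so it cannot be assigned to either, and no measurement shown offers an explanation for these readings.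

The compounds shown leave open whether another group at this place on the benzyl ring, such as an amine or a carboxylic acid, would move the number beyond the scatter. They also leave open whether 4-fluorobenzyl or 4-chlorophenyl would fall nearer to compound 2 or to compound 4.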